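A Nitrile at the Chain End of Compound 2

The source may report more compounds than this note shows. Statements on the series, on what has been measured and on what is new or still open speak of the compounds shown alone.

Compound 1, `Nc1cc(N)nc(SCCCCc2ccccc2)n1`: > 100000 nM
Compound 2, `CCCCCCCc1nc(O)cc(O)n1`: 12.7 nM

Of the compounds shown here, two have been measured in a functional assay on HEK293 cells for agonist activity at G-protein coupled receptor 84 (Homo sapiens), read by calcium flux; a higher number here means that more compound is needed for the effect, a lower number that less compound is needed. For compound 1 the result is a limit of the assay rather than a number, > 100000 nM, which is the case described by the limit of > 100000 nM in this assay, at which 1 of the 2 values shown sits. Going by the values given here, compound 2 gives 12.7 nM in this assay, and it is the only numerical value there is; no step between measured compounds can be read from these two.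

Compound 3, `N#CCCCCc1nc(O)cc(O)n1`, has not yet been measured. It differs from compound 2 in one place: cyano in place of propyl on a saturated chain carbon, four bonds along the chain from an aromatic carbon. Among the compounds with values here, no measured pair shows what such a change does on this core, so the expectation rests on compound 2 alone. The expected step in this assay from compound 2 to compound 3 is a 39-fold higher number from compound 2 to compound 3 (1.60 log units; beyond the scatter), toward more compound being needed and larger than the scatter. Compound 3 is accordingly estimated at 500 nM, within a range from 50 nM to 5000 nM.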

Compound 3, half-maximal effective concentration: > 100000 nM
Compound 3 was reported as a limit; the forecaster's own chance of this, stated with the estimate: 15%; middle value at least 200-fold (2.30 log units) from the limit.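

In this assay, going by these compounds alone, putting cyano in place of propyl on a saturated chain carbon, four bonds along the chain from an aromatic carbon, gives an at least 7800-fold higher number from compound 2 to compound 3 (3.89 log units; beyond the scatter), the first step that can be read at this position. It shows that the potency of compound 2 does not survive this change at the chain end. Compound 3 is reported as a limit of the assay and not as a number, so the step gives only a lower bound on the change: the limit of > 100000 nM in this assay, at which 2 of the 3 values shown sit.

The compounds shown leave open whether the nitrile itself or the loss of the propyl carbons accounts for the step. Nor do they tell how an amine, a carboxylic acid or a longer chain ending in a nitrile would fare at this place.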